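The compounds below may be only part of what the source reports. "The series", "measured", "known", "first", "only" and "open" are said of these compounds alone.

In an ADME assay on KB cells (Homo sapiens) for cytotoxicity, read by MTT assay, with a stated time of 72 h (a higher number here means a weaker inhibitor, a lower number a stronger inhibitor), compound 1 `COc1ccc(C2=C(c3cc(OC)c(OC)c(OC)c3)C(=O)C(O[SiH2]C(C)(C)C)C2)cc1OC(C)C` gives 7.5 ug/mL, the highest of the two numbers shown here. Compound 3 `COc1ccc(C2=C(c3cc(OC)c(OC)c(OC)c3)C(=O)C(O[SiH2]C(C)(C)C)C2)cc1` gives 7 ug/mL, and the step of a 1.1-fold lower number from compound 1 to compound 3 (0.03 log units; within the scatter) stays within the scatter. Compound 2 `COc1ccc(C2=C(c3cc(OC)c(OC)c(OC)c3)CC(O)C2=O)cc1N` is reported only as a limit, < 1 ug/mL, and not as a number; this is the limit of < 1 ug/mL in this assay, at which 1 of the 3 values shown sits. Compound 4 `COc1ccc(C2=C(c3cc(OC)c(OC)c(OC)c3)C(=O)C(O)C2)cc1OC(C)C` has not yet been measured in this assay. It differs from compound 1 by a hydrogen atom in place of a group of 5 heavy atoms (4 carbon, 1 silicon; no ring), on an oxygen on a saturated carbon. Going by the values given here, no measured step touches this oxygen: the single measured step, from compound 1 to compound 3, concerns the aromatic isopropoxy and was within the scatter, so it says nothing about the present change. Among the compounds with values here, compound 2 also carries a free hydroxyl on a saturated carbon, and its limit suggests a stronger inhibitor than compound 1, though no step between compound 2 and either compound 1 or compound 4 has been counted, so this is only a hint. Compound 4 is therefore estimated at 2 ug/mL, expected to fall between 0.5 ug/mL and 8 ug/mL. That estimate means an expected step of a 3.8-fold lower number from compound 1 to compound 4 (0.57 log units; beyond the scatter), toward a lower number.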

Compound 4, half-maximal inhibitory concentration: > 100 ug/mL
Compound 4 gave a limit, no number; the forecaster's own chance of this, stated with the estimate: 25%; middle value at least 50-fold (1.69 log units) from the limit.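

Going by these compounds alone, the oxygen on a saturated carbon proves to be a sensitive place in this assay, which the earlier compounds could not show. Within the data shown here, putting a hydrogen there in place of the group of 5 heavy atoms (4 carbon, 1 silicon; no ring) gives an at least 13-fold higher number from compound 1 to compound 4 (1.12 log units; beyond the scatter), a large step beyond the scatter, whereas the only earlier step, a 1.1-fold lower number from compound 1 to compound 3 (0.03 log units; within the scatter), lay at the aromatic isopropoxy and stayed within it. As far as these compounds go, compound 4 gives > 100 ug/mL, which is a limit of the assay and not a number, so the full size of the step stays unknown.

The compounds shown leave open whether a methyl ether, an acetate ester or a longer carbon chain on this oxygen would keep the value of compound 1. They also leave open whether the aromatic isopropoxy has any bearing once this oxygen carries hydrogen.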